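Cytotoxicity series: aryl replacement at the saturated ring carbon

The compounds below may be only part of what the source reports. "The series", "measured", "known", "first", "only" and "open" are said of these compounds alone.

compound 1 `CCOC(=O)C12C(=O)OCC=C1COC2c1ccc(F)cc1` — assay limit only, > 1000000 nM
compound 2 `CCOC(=O)C12C(=O)OCC=C1COC2c1ccc(Br)cc1` — assay limit only, > 1000000 nM

In a functional assay on A549 cells (Homo sapiens) for cytotoxicity, read by MTT assay (on this read-out higher numbers stand for weaker inhibition and lower numbers for stronger inhibition), compound 1 returns only a limit, > 1000000 nM. In this assay compound 2 likewise returns only a limit, > 1000000 nM. The step that the two limits leave unreadable from compound 1 to compound 2 cannot be read, since both values sit at the limit of > 1000000 nM in this assay, at which 2 of the 2 values shown sit. Compound 2 therefore stands at the assay limit with no numbered value. Compound 3 `CCOC(=O)C12C(=O)OCC=C1COC2c1ccco1` differs from compound 2 by furan-2-yl in place of 4-bromophenyl on a saturated ring carbon. Within the data shown here, no measured step bears on this change, and the single measured step is unreadable. For compound 3 the expected value is 1000000 nM, within 300000 nM to 5000000 nM. The step expected is a number no higher from compound 2 to compound 3 (the limit leaves the size open), none beyond the scatter.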

Compound 3, half-maximal inhibitory concentration: > 1000000 nM
Compound 3 gave a limit, no number; the forecaster's own chance of this, stated with the estimate: 85%; the middle value lies on the limit itself.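

The steps from compound 1 and compound 2 to compound 3 cannot be read, since all three compounds sit at one limit: the limit of > 1000000 nM in this assay, at which 3 of the 3 values shown sit.
The compounds shown leave open how 4-fluorophenyl, 4-bromophenyl and furan-2-yl on this saturated ring carbon rank against one another.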